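Cytotoxicity notes on a small series, with one estimate

A few compounds are considered here, and "the series" means these few. Any claim that something is new, unique, unknown or untested is made for them only; others in the source may bear on it.

Measured so far:
compound 1 `C=CCOc1cc(OC)c(C(=O)/C=C/c2ccccc2Br)c(OCC=C)c1`, 13900 nM in an ADME assay on Vero cells (Chlorocebus sabaeus) for cytotoxicity, read by MTT assay; a lower number here means a stronger inhibitor, a higher number a weaker inhibitor
compound 2 `C=CCOc1cc(OC)c(C(=O)/C=C/c2ccc(C(F)(F)F)cc2)c(OCC=C)c1`, 7200 nM
compound 3 `C=CCOc1cc(OC)c(C(=O)/C=C/c2cccc(OC)c2)c(OCC=C)c1`, 142000 nM

Compound 3 gives the highest number of the three in this assay: a 10-fold higher number from compound 1 to compound 3 (1.01 log units; beyond the scatter) and a 20-fold higher number from compound 2 to compound 3 (1.29 log units; beyond the scatter), both large, while a 1.9-fold lower number from compound 1 to compound 2 (0.29 log units; within the scatter). Compound 4 `C=CCOc1cc(OC)c(C(=O)/C=C/c2ccc(OC)cc2)c(OCC=C)c1` differs from compound 3 only in the position of one group: 4-methoxyphenyl in place of 3-methoxyphenyl on a double-bonded chain carbon bound to a double-bonded chain carbon. For the measured compounds named here, no measured step moves a methoxy group from one ring position to another, so none bears directly on this change; the measured steps all swap one aryl group for another with different atoms. With the atoms unchanged, the step is expected to be a 1.4-fold lower number from compound 3 to compound 4 (0.15 log units; within the scatter) in this assay, hardly beyond the scatter. Compound 4 is therefore estimated at 100000 nM, with a range from 30000 nM to 300000 nM.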

Compound 4, half-maximal inhibitory concentration: 99900 nM
Compound 4: the middle estimate sits 1.0-fold (0.00 log units) above what was measured; the measured number falls inside the stated range.
By their numbers in this assay, from the lowest: compounds 2 and 1 (each within the scatter of the next); then compounds 4 and 3 (each within the scatter of the next).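

In this assay, moving the methoxy group from 3-methoxyphenyl to 4-methoxyphenyl gives a 1.4-fold lower number from compound 3 to compound 4 (0.15 log units; within the scatter) and so shows that, at this place on the double-bonded chain carbon, the position of this group has no effect beyond the scatter. The steps of a 14-fold higher number from compound 2 to compound 4 (1.14 log units; beyond the scatter) and a 7.2-fold higher number from compound 1 to compound 4 (0.86 log units; beyond the scatter) show that the 4-methoxyphenyl compound, like compound 3, stays apart from the trifluoromethyl and bromo compounds. No measurement here accounts for these differences.

Going by these compounds, whether an amine or a longer alkoxy chain in place of methoxy on the aromatic carbon would stay with the two methoxy compounds remains open.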